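The source may report more compounds than this note shows. Statements on the series, on what has been measured and on what is new or still open speak of the compounds shown alone.

Measured so far:

Compound 1 `COC(=O)[C@@]1(C)CCC=C2[C@@H]1CC[C@@H](C)[C@]2(C)Cc1c(C)[nH]c2ccc(Cl)cc12` gives 12000 nM.
Compound 2 `COC(=O)[C@@]1(C)CCC=C2[C@@H]1CC[C@@H](C)[C@]2(C)Cc1c(C)[nH]c2ccc(F)cc12` gives 11000 nM.
Compound 3 `COC(=O)[C@@]1(C)CC[C@@H]2C3=C1CC[C@@H](C)[C@]3(C)C[C@@H]1c3cc(Cl)ccc3N[C@H]21` gives 23000 nM.

All three were tested in a functional assay on HeLa cells (Homo sapiens) for inhibition, read by sulforhodamine B assay, with a stated time of 48 h; on this read-out higher numbers stand for weaker inhibition of growth and lower numbers for stronger inhibition of growth. Compound 1 and compound 2 share one core and differ by fluoro in place of chloro on an aromatic carbon. That change gave a 1.1-fold lower number from compound 1 to compound 2 (0.04 log units; within the scatter), so the two numbers are not distinguishable here. Compound 3 is built on a different core; how the two cores differ is not broken down here. The number for compound 3 lies within the scatter of the number for compound 1, while it lies beyond the scatter of the number for compound 2, so compound 3 reads as a weaker inhibitor of growth than compound 2.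

Compound 4 `COC(=O)[C@@]1(C)CC[C@@H]2C3=C1CC[C@@H](C)[C@]3(C)C[C@@H]1c3cc(F)ccc3N[C@H]21` has not yet been measured. It differs from compound 3 by fluoro in place of chloro on an aromatic carbon. This is the same kind of change as that from compound 1 to compound 2, though not the same: there the ring carrying the halogen is part of a fused or bridged system of two rings, here of five rings. Beside the step from compound 1 to compound 2, which was a 1.1-fold lower number from compound 1 to compound 2 (0.04 log units; within the scatter), compound 4 is expected to show a 1.1-fold lower number from compound 3 to compound 4 (0.04 log units; within the scatter), a step that rests only on the near-null result of that earlier pair. Compound 4 is therefore estimated at 21000 nM, with an expected range from 9000 nM to 50000 nM.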

Compound 4, concentration for 50% growth inhibition: 20000 nM
For compound 4 the middle estimate is 1.1-fold (0.02 log units) above the measured one, and the stated range covers the measured number.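

In this assay, fluoro in place of chloro on an aromatic carbon of the second core gave a 1.2-fold lower number from compound 3 to compound 4 (0.06 log units; within the scatter), so the two numbers cannot be told apart. Set beside the earlier pair, the change reads the same on both cores: the same change on two cores in this assay, a 1.1-fold lower number (0.04 log units; within the scatter) from compound 1 to compound 2 and a 1.2-fold lower number (0.06 log units; within the scatter) from compound 3 to compound 4, 1.1-fold (0.02 log units) apart, within the scatter of two such steps. This shows that, in this assay, the near-null result of this one halogen exchange carries from one core to the other; it does not show that a change with a step beyond the scatter would carry in the same way, since neither step here rises above the scatter, and it says nothing about what either halogen contributes compared with a bare aromatic carbon.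

The compounds shown leave open whether a different group on that aromatic carbon, such as bromo, methoxy or an amine, would move the number beyond the scatter on either core. They also leave open whether a carboxylic acid or an amide in place of the methyl ester would change the reading, and whether any such change would then hold from one core to the other.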